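The source may hold more compounds than are shown below. What is called first, only, known or untested is meant among the compounds shown, and "the series" means these compounds.

Compound 1 `CN(C)C(=O)c1cc2cnc(Nc3ccc(NC(=O)C4(C(=O)Nc5ccccc5)CC4)cc3)nc2n1C1CCCC1` gives 52.8% in a functional assay on T47D cells (Homo sapiens) for inhibition, read by CCK-8 assay, with a stated time of 72 h, tested at 1 uM; a lower number here means less inhibition of growth, a higher number more inhibition of growth at the concentration tested. Compound 2 `CN(C)C(=O)c1cc2cnc(Nc3ccc(NC(=O)C4(C(=O)Nc5cccc(O)c5)CC4)cc3)nc2n1C1CCCC1` gives 80.7%. Compound 3 `CN(C)C(=O)c1cc2cnc(Nc3ccc(NC(=O)C4(C(=O)Nc5cccc(Br)c5)CC4)cc3)nc2n1C1CCCC1` gives 29.1%.

Compound 1 thus stands in the middle of the three numbers, with compound 2 above it and compound 3 below. Compound 4 `Cc1ccc(NC(=O)C2(C(=O)Nc3ccc(Nc4ncc5cc(C(=O)N(C)C)n(C6CCCC6)c5n4)cc3)CC2)cc1` differs from compound 1 by methyl in place of hydrogen on an aromatic carbon. The measured steps from compound 1 that touch this outer aromatic ring are a number 27.9 percentage points higher from compound 1 to compound 2 (beyond the scatter) and a number 23.7 percentage points lower from compound 1 to compound 3 (beyond the scatter), one upward and one downward, so neither group resembles a methyl and no direct guide exists. A step of modest size in either direction, or none beyond the scatter, is plausible; a methyl shares nothing counted with the hydroxy that raised inhibition. Compound 4 is therefore expected to give 45%, between 25% and 65%, a step of a number 7.8 percentage points lower from compound 1 to compound 4 (within the scatter).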

Compound 4, percent growth inhibition at one concentration: 47.9%
Beside the measured number, compound 4's estimate is 2.9 percentage points below it, and the stated range covers the measured number.
By their numbers in this assay, from the lowest: compound 3; then compounds 4 and 1 (each within the scatter of the next); then compound 2.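

In this assay, within the data shown here, a methyl on this ring, para to a large group, is the first change to stay within the scatter: a number 4.9 percentage points lower from compound 1 to compound 4 (within the scatter). The other two steps, a number 18.8 percentage points higher from compound 3 to compound 4 (beyond the scatter) and a number 32.8 percentage points lower from compound 2 to compound 4 (beyond the scatter), change both the group and its place on the ring, so they do not separate those two effects. No supporting evidence explains these differences. The compounds shown leave open how 3-methylphenyl would compare with the 3-hydroxyphenyl and 3-bromophenyl groups. They also leave open what an amine or a carboxylic acid would do on this ring.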